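Compound 2 and Its Dibromo Counterpart

The compounds below may be only part of what the source reports. "The series", "measured", "known", "first", "only" and "open" are said of these compounds alone.

In an ADME assay on MT4 cells (Homo sapiens) for inhibition, read by MTT assay, with a stated time of 5 days (on this read-out lower numbers stand for higher toxicity in this test and higher numbers for lower toxicity in this test), compound 1 `Cc1cc(C#N)cc(C)c1Oc1cc(Nc2ccc(C#N)cc2)ncc1[N+](=O)[O-]` gives 36100 nM, compound 2 `Cc1cc(Cl)cc(C)c1Oc1cc(Nc2ccc(C#N)cc2)ncc1[N+](=O)[O-]` gives 11100 nM and compound 3 `COc1cccc(OC)c1Oc1cc(Nc2ccc(C#N)cc2)ncc1[N+](=O)[O-]` gives 319000 nM. Compound 2 therefore has the lowest of the three numbers, and it is the starting point here. Compound 4 `Cc1cc(Br)c(Oc2cc(Nc3ccc(C#N)cc3)ncc2[N+](=O)[O-])c(Br)c1` keeps the rest of compound 2 but carries 2,6-dibromo-4-methylphenyl in place of 4-chloro-2,6-dimethylphenyl on an oxygen on an aromatic ring.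

Among the compounds with values here, only one measured step offers direct guidance: a 3.3-fold lower number from compound 1 to compound 2 (0.51 log units; beyond the scatter), a modest change beyond the scatter, with chloro in place of cyano on an aromatic carbon. It is a single swap, whereas compound 4 differs in a whole group, so it gives no firm direction. The much higher number of compound 3, 319000 nM, warns that the range should stay wide. No shift beyond the scatter is therefore expected, and the estimated change is a 1.2-fold higher number from compound 2 to compound 4 (0.07 log units; within the scatter). For compound 4 the expected value is 13000 nM, with an estimated range from 4000 nM to 45000 nM.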

Compound 4, half-maximal cytotoxic concentration: 23600 nM
Beside the measured number, compound 4's estimate is 1.8-fold (0.26 log units) below it, within the range that was stated.
By their numbers in this assay, from the lowest: compound 2; then compounds 4 and 1 (each within the scatter of the next); then compound 3.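

In this assay the exchange of the whole group on the oxygen, 4-chloro-2,6-dimethylphenyl for 2,6-dibromo-4-methylphenyl, gives a 2.1-fold higher number from compound 2 to compound 4 (0.33 log units; beyond the scatter) and this modest move goes beyond the scatter. Within the data shown here, the earlier step at this group changed only a single atom group, whereas here the chlorine and the methyl groups change together, with the heavy-atom count of 9 and the absence of hydrogen-bond donors and acceptors staying the same in both groups. No measurement among these compounds gives a reason for the shift.

The compounds shown do not separate the effect of adding the bromine atoms from that of losing the chlorine, as both happen in this one step. Going by these compounds, how the number would respond to an amine or a carboxylic acid on this phenyl ring also remains open.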